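Straightening the tetrazole-bearing chain of compound 1

A few compounds are considered here, and "the series" means these few. Any claim that something is new, unique, unknown or untested is made for them only; others in the source may bear on it.

Compound 1 `CCCc1c(COc2ccc(C(=O)C(C)(C)Cc3nnn[nH]3)cc2)ccc(C(C)=O)c1O` holds the lower of the two single numbers in a functional assay on ileum (Cavia porcellus) with cysteinyl leukotriene receptor (Homo sapiens) as the target (on this read-out higher numbers stand for higher potency (the scale is a negative logarithm) and lower numbers for lower potency), where compound 1 gives 6.93. Compound 3 `CCCCc1c(COc2ccc(C(=O)CCCCC(=O)O)cc2)ccc(C(C)=O)c1O` stands above it, beyond the scatter, and compound 3 gives 7.28. Compound 2 `CCc1c(COc2ccc(C(=O)CC(C)(C)CC(=O)O)cc2)ccc(C(C)=O)c1O` has no single number but several entries, (the several entries of compound 2 in this assay, 7.46; 7.6 (2 entries)), and compound 2 gives 7.46; 7.6 (2 entries). Compound 4 `CCCc1c(COc2ccc(C(=O)CCCCc3nnn[nH]3)cc2)ccc(C(C)=O)c1O`, not yet measured, keeps every atom of compound 1 but joins them differently: 4-(1H-tetrazol-5-yl)butyl in place of 1-((1H-tetrazol-5-yl)methyl)-1-methylethyl on a carbonyl carbon. Within the data shown here, no measured pair differs in this one place, so no step can be read off; a small rise, within or just beyond the scatter, is expected in this assay, a number 0.27 log units higher from compound 1 to compound 4 (within the scatter). Compound 4 is estimated to give 7.2, with a range from 6.7 to 7.7.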

Compound 4, negative logarithm of the antagonist equilibrium constant: 7.28
For compound 4 the middle estimate is 0.08 log units below the measured one; low and high end bracket the measured number.
By their numbers in this assay, from the lowest: compound 1; then compounds 3 and 4 (each within the scatter of the next).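

Among these compounds, the first direct step at this position is a number 0.35 log units higher from compound 1 to compound 4 (beyond the scatter) in this assay. The atoms and the counts of the group on the carbonyl carbon stay the same, so joining them as 4-(1H-tetrazol-5-yl)butyl rather than 1-((1H-tetrazol-5-yl)methyl)-1-methylethyl is enough to move the number. Nothing at hand bears on the reason for this step.

Still open, as far as these compounds go, is whether a single methyl branch on the butyl chain keeps this gain. Also open, from the compounds shown here alone, is how a carboxylic acid in place of the tetrazole, or a longer chain, would read on the core of compound 4.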